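The source may report more compounds than this note shows. Statements on the series, on what has been measured and on what is new or still open speak of the compounds shown alone.

Compound 1, `CN(Cc1ccccc1)C(=S)N/N=C\c1c[nH]c2ccccc12`, was examined in an ADME assay on KB cells (Homo sapiens) for cytotoxicity, read by MTT assay, with a stated time of 44 h; a lower number here means a stronger inhibitor, a higher number a weaker inhibitor. In this assay compound 1 gives only a limit, > 100000 nM, so no number stands for it. Compound 2, `Cc1ccc(NC(=S)N/N=C\c2c[nH]c3ccccc23)cc1`, carries the shared core with a different group on it. In this assay compound 2 likewise gives only a limit, > 100000 nM. Both values therefore sit at the limit of > 100000 nM in this assay, at which 2 of the 2 values shown sit, and no difference between compound 1 and compound 2 can be read from them. Compound 3, `CCCCN(C)C(=S)N/N=C\c1c[nH]c2ccccc12`, has not yet been measured in this assay. Its structure differs from that of compound 1 in one place: propyl in place of phenyl on a saturated chain carbon bound to an amide-type nitrogen, or, cut one bond further out, benzyl to butyl. Within the data shown here, no measured pair shows a step of this kind, and the numbers at hand give no direction for it. On that basis compound 3 is expected to give 150000 nM in this assay, with a range from 50000 nM to 500000 nM, and most probably again only a limit. The step from compound 1 to compound 3 that this estimate means, a step that the limit leaves unreadable from compound 1 to compound 3, is expected to be none beyond the scatter.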

Compound 3, half-maximal inhibitory concentration: > 100000 nM
Compound 3: no number, only a limit (the forecaster's own chance of this, stated with the estimate: 80%); the middle value lies beyond the limit too.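

No step from compound 1 to compound 3 can be read, as both give only a limit in this assay, and compound 2 gives one too: the limit of > 100000 nM in this assay, at which 3 of the 3 values shown sit.

The compounds shown leave open whether benzyl and butyl differ at all in this assay, and whether any group on the shared core would give a number rather than a limit.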